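The source may hold more compounds than are shown below. What is called first, only, known or untested is meant among the compounds shown, and "the series" means these compounds.

Measured in a physicochemical assay, with a stated time of 6 min; on this read-out lower numbers stand for stronger inhibition and higher numbers for weaker inhibition:
- compound 1 `COc1ccc(NC(=O)Nc2nc(-c3cc4ccccc4o3)cs2)cc1`: 17400 nM.
- compound 2 `COc1cccc(NC(=O)Nc2nc(-c3cc4ccccc4o3)cs2)c1`: 200 nM.
- compound 3 `COc1cccc(NC(=O)Nc2nc(-c3cc4cc(Br)ccc4o3)cs2)c1`: > 200000 nM, a limit and not a number.

Compound 2 has the lowest of the exact numbers, so it is the strongest inhibitor here. Compound 4 `Cc1ccc(NC(=O)Nc2nc(-c3cc4ccccc4o3)cs2)cc1` has not been measured. It differs from compound 2 by 4-methylphenyl in place of 3-methoxyphenyl on an amide-type nitrogen, with 4-methylphenyl in place of 3-methoxyphenyl on an amide-type nitrogen.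

The most relevant evidence is a large step, an 87-fold lower number from compound 1 to compound 2 (1.94 log units; beyond the scatter), at this same place. Compound 1 carries 4-methoxyphenyl, the closest match to the new group. The equally large step an at least 1000-fold higher number from compound 2 to compound 3 (3.00 log units; beyond the scatter) lies elsewhere on the molecule and bears less directly.

A large rise, beyond the scatter, is therefore expected, with an estimated step of a 50-fold higher number from compound 2 to compound 4 (1.70 log units; beyond the scatter). For compound 4 the estimated value is 10000 nM, with an expected range of 2000 nM to 50000 nM.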

Compound 4, half-maximal inhibitory concentration: 500 nM
Compound 4: middle estimate off by 20-fold (1.30 log units), on the high side; measured number outside the range, below it.
By their numbers in this assay, from the lowest: compound 2; then compound 4; then compound 1. At a limit, above all of these: compound 3.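

In this assay, changing 3-methoxyphenyl to 4-methylphenyl on the amide-type nitrogen gives only a 2.5-fold higher number from compound 2 to compound 4 (0.40 log units; beyond the scatter), so a group carried as in 4-methylphenyl need not cost much here. Exchanging methoxy for methyl gives a 35-fold lower number from compound 1 to compound 4 (1.54 log units; beyond the scatter), which shows that the weak result of compound 1 depends on the methoxy group itself and not only on where it sits. Nothing measured here explains why these two groups differ so much.

Still open, going by these compounds, is how 3-methylphenyl would compare with 3-methoxyphenyl. It is also unknown whether an amine or a carboxylic acid in place of the methyl would keep the number low.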